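The source may hold more compounds than are shown below. What is called first, only, known or untested is meant among the compounds shown, and "the series" means these compounds.

Of the compounds shown here, three share one core and have been tested in an ADME assay on HepG2 cells (Homo sapiens) for cytotoxicity, read by luminescence, CellTiter-Glo and ATP content, with a stated time of 72 h; a lower number here means that less compound is needed, a higher number that more compound is needed for the effect. Compound 1 `COc1cccc(CNCCCNc2ccnc3cc(C4CCCCC4)ccc23)c1O` gives 1080 nM. Compound 2 `COc1ccc(F)cc1CNCCCNc1ccnc2cc(C3CCCCC3)ccc12` gives 2290 nM, and compound 3 `COc1cccc(CNCCCNc2ccnc3cc(Oc4ccc(C(C)(C)C)cc4)ccc23)c1O` gives 1500 nM. Among these three numbers compound 2 stands highest: its distance to compound 3 is within the scatter, while the step of a 2.1-fold higher number from compound 1 to compound 2 (0.33 log units; beyond the scatter) lies beyond it. Compound 1 and compound 3 differ only at the aromatic carbon of the core, and that step, a 1.4-fold higher number from compound 1 to compound 3 (0.14 log units; within the scatter), stays within the scatter.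

The compound still to be measured is compound 4 `COc1ccc(F)cc1CNCCCNc1ccnc2cc(-c3cccc4ccccc34)ccc12`. It differs from compound 2 at that same aromatic carbon: naphthalen-1-yl in place of cyclohexyl on an aromatic carbon. Within the data shown here, the one measured step that bears on this place is a 1.4-fold higher number from compound 1 to compound 3 (0.14 log units; within the scatter), where an exchange of the cyclohexyl for a larger group left the number essentially unchanged. Among the measured compounds shown here, no measured pair shows what a naphthalen-1-yl does at this place, so the expectation rests on that single step alone. The change from compound 2 to compound 4 is therefore expected to be small, a step of about a 1.2-fold higher number from compound 2 to compound 4 (0.07 log units; within the scatter), with no clear direction beyond the scatter. For compound 4 the estimated value in this assay is 2700 nM, within a range from 1300 nM to 5600 nM.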

Compound 4, half-maximal effective concentration: 16000 nM
Beside the measured number, compound 4's estimate is 5.9-fold (0.77 log units) below it; the whole stated range lies below it.
By their numbers in this assay, from the lowest: compounds 1, 3 and 2 (each within the scatter of the next, the first and the last beyond it); then compound 4.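

In this assay the exchange of cyclohexyl for naphthalen-1-yl gives a 7.0-fold higher number from compound 2 to compound 4 (0.84 log units; beyond the scatter) and so shows that this aromatic carbon is not indifferent to the group it carries: far more compound is needed for the effect. The earlier step at this place, a 1.4-fold higher number from compound 1 to compound 3 (0.14 log units; within the scatter) with 4-(tert-butyl)phenoxy as the incoming group, stayed within the scatter and gave no sign of such sensitivity, although the other end of the molecule also differs between that pair and this one, so the response here depends at least on which group enters, and perhaps also on its surroundings. Nothing available explains why naphthalen-1-yl moves the number so much.

The compounds shown leave open whether any aromatic ring of carbon at this place has the same effect or whether it takes the two fused rings of naphthalen-1-yl, a question that a plain phenyl or a naphthalen-2-yl group could help to settle. They also leave open whether naphthalen-1-yl would shift the number as far in a compound carrying the 2-hydroxy-3-methoxyphenyl group of compound 1.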